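A few compounds are considered here, and "the series" means these few. Any claim that something is new, unique, unknown or untested is made for them only; others in the source may bear on it.

Measured so far in a functional assay on A549 cells (Homo sapiens) for cytotoxicity, read by sulforhodamine B assay, with a stated time of 48 h, tested at 0.1 uM; on this read-out lower numbers stand for a stronger effect and higher numbers for a weaker effect at the one concentration tested:

Compound 1, `COc1cc(-c2cc(/C=C/C(=O)c3ccc(N)cc3)[nH]n2)cc(OC)c1OC`: 94%
Compound 2, `COc1cc(-c2cc(/C=C/C(=O)c3ccc(Cl)c(Cl)c3)[nH]n2)cc(OC)c1OC`: 99%
Compound 3, `COc1ccc(C(=O)/C=C/c2cc(-c3cc(OC)c(OC)c(OC)c3)n[nH]2)cc1`: 101%

The three numbers lie within the scatter of one another. Compound 3 stands nearest to compound 2, with a number 2 percentage points higher from compound 2 to compound 3 (within the scatter), and furthest from compound 1, with a number 7 percentage points higher from compound 1 to compound 3 (within the scatter); neither gap means a real difference on this read-out.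

Compound 4, `COc1ccc(C(=O)/C=C/c2cc(-c3cc(OC)c(OC)c(OC)c3)n[nH]2)cc1OC`, is the next compound. It differs from compound 3 in one place: methoxy in place of hydrogen on an aromatic carbon.

Among the measured compounds shown here, no measured step makes exactly this change. The two that touch the same part of the molecule are a number 2 percentage points higher from compound 2 to compound 3 (within the scatter), where 4-methoxyphenyl replaced 3,4-dichlorophenyl on the carbonyl carbon, and a number 7 percentage points higher from compound 1 to compound 3 (within the scatter), where methoxy replaced amino on that ring; a third, a number 5 percentage points higher from compound 1 to compound 2 (within the scatter), also stayed within the scatter. Every change on this ring so far has left the read-out essentially flat, so nothing in these data points to a shift beyond the scatter in either direction for compound 4.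

Compound 4 is therefore expected to give 99%, with a range from 88% to 110%. The step of a number 2 percentage points lower from compound 3 to compound 4 (within the scatter) is expected to stay within the scatter.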

Compound 4, a percentage reported as activity, at one concentration (the size of the read-out at that concentration, not a potency): 98%
Compound 4: middle estimate off by 1 percentage points, on the high side; measured number inside the range.
By their numbers in this assay, from the lowest: compounds 1, 4, 2 and 3 (each within the scatter of the next).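

In this assay, among the compounds shown here, the methoxy placed ortho to a methoxy group and meta to a large group gives a number 3 percentage points lower from compound 3 to compound 4 (within the scatter), so turning 4-methoxyphenyl into 3,4-dimethoxyphenyl adds a group at this position, whereas the earlier steps exchanged whole aryl groups or one substituent for another, and the read-out still shows no real difference. The new aryl group also cannot be told apart from the two others, with a number 1 percentage points lower from compound 2 to compound 4 (within the scatter) against 3,4-dichlorophenyl and a number 4 percentage points higher from compound 1 to compound 4 (within the scatter) against 4-aminophenyl, so this ring has now carried four different substitution patterns across the compounds shown without any step leaving the scatter. Nothing available here bears on why this position makes no measurable difference.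

The compounds shown leave open whether any group at this position, such as a carboxylic acid, a dimethylamino group or a longer chain like butoxy, would move the number beyond the scatter. They also leave open whether changes to the 3,4,5-trimethoxyphenyl group or the shared core would do so, and whether the four compounds would separate at another concentration in this assay.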